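Amide-nitrogen aryl variation: cytotoxicity notes

The source may report more compounds than this note shows. Statements on the series, on what has been measured and on what is new or still open speak of the compounds shown alone.

Measured so far:
compound 1 `O=C(CSc1snnc1-c1ccc(Br)cc1Br)Nc1ccccc1[N+](=O)[O-]`: > 235000 nM
compound 2 `Cc1cccc(NC(=O)CSc2snnc2-c2ccc(Br)cc2Br)c1C`: 241000 nM

In an ADME assay on MT4 cells (Homo sapiens) for cytotoxicity, read by MTT assay, with a stated time of 5 days (on this read-out higher numbers stand for lower toxicity in this test and lower numbers for higher toxicity in this test), compound 1 reaches only a limit of the test, > 235000 nM. For the measured compounds named here, compound 2 gives 241000 nM in this assay, and this is the only actual number in the set. Compound 1 contributes the other value, a limit (the limit of > 235000 nM in this assay, at which 1 of the 2 values shown sits). The step that the limit leaves unreadable from compound 1 to compound 2, 2,3-dimethylphenyl in place of 2-nitrophenyl on an amide-type nitrogen, thus has no readable size.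

Compound 3 `Cc1ccc(NC(=O)CSc2snnc2-c2ccc(Br)cc2Br)cc1` carries the change (4-methylphenyl in place of 2,3-dimethylphenyl on an amide-type nitrogen). Going by the values given here, no measured step bears on it directly: the single step is unreadable, so the data give no direction. With nothing pointing either way, the swap to 4-methylphenyl is expected to leave the read-out within the usual scatter. The expected step from compound 2 to compound 3 is therefore a 1.0-fold lower number from compound 2 to compound 3 (0.00 log units; within the scatter). Compound 3 is estimated at 240000 nM, with a range from 120000 nM to 480000 nM, and a real chance that only a limit is reported.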

Compound 3, half-maximal cytotoxic concentration: 24000 nM
Beside the measured number, compound 3's estimate is 10-fold (1.00 log units) above it, and the stated range ends above it.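

In this assay, the aryl group on the amide-type nitrogen can clearly move the read-out: 4-methylphenyl in place of 2,3-dimethylphenyl gives a 10-fold lower number from compound 2 to compound 3 (1.00 log units; beyond the scatter). Measured against 2-nitrophenyl, the same 4-methylphenyl group gives an at least 9.7-fold lower number from compound 1 to compound 3 (0.99 log units; beyond the scatter), which leaves compound 3 with the lowest number of the three and so the highest toxicity in this test, with the rest of the structure unchanged in both comparisons. Compound 1 stands at a limit, and the step from compound 1 to compound 2 cannot be read: the limit of > 235000 nM in this assay, at which 1 of the 3 values shown sits.

The compounds shown do not separate what in the change from 2,3-dimethylphenyl to 4-methylphenyl carries the step, and a single pair gives no rule for other aryl groups on this nitrogen. Going by these compounds, how an unsubstituted phenyl, a 4-aminophenyl or a 4-carboxyphenyl at this place would read, and whether any of them would return the number towards that of compound 2 or stay near that of compound 3, remains open.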